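The source may hold more compounds than are shown below. What is called first, only, known or untested is meant among the compounds shown, and "the series" means these compounds.

Compound 1 `O=S(=O)(/C=C/c1ccc(F)cc1)Cc1ccc(Nc2ncnc3ccccc23)cc1` and compound 2 `O=S(=O)(/C=C/c1ccc(Cl)cc1Cl)Cc1ccc(Nc2ncnc3ccccc23)cc1` share one core and differ only in the group on the ethenyl chain: 2,4-dichlorophenyl in place of 4-fluorophenyl on a double-bonded chain carbon bound to a double-bonded chain carbon. In a functional assay on SK-OV-3 cells (Homo sapiens) (on this read-out higher numbers stand for weaker inhibition of growth and lower numbers for stronger inhibition of growth), compound 1 gives 2000 nM, and compound 2 gives 2000 nM, so that no change at the digits printed from compound 1 to compound 2 (within the scatter). Compound 3 `O=S(=O)(/C=C/c1ccc(F)cc1Cl)Cc1ccc(Nc2ncnc3ccccc23)cc1` carries an added substituent relative to compound 1: chloro in place of hydrogen on an aromatic carbon. In this assay compound 3 gives 44000 nM, and a 22-fold higher number from compound 1 to compound 3 (1.34 log units; beyond the scatter). Compound 4 `O=S(=O)(/C=C/c1ccc(Cl)cc1Cl)Cc1ccc(Nc2ncnc3cc(Cl)ccc23)cc1`, not yet measured, arises from compound 2 by the same kind of change: chloro in place of hydrogen on an aromatic carbon. The place is not the same, however: in compound 3 the chloro stands ortho to a large group and meta to a fluoro group, whereas in compound 4 it stands on a ring that is part of a fused or bridged system of two rings, meta to a fused ring and para to a fused ring. Among the measured compounds shown here, the only measured example of this kind of change is a 22-fold higher number from compound 1 to compound 3 (1.34 log units; beyond the scatter), but it concerns another ring, so the result for compound 4 remains uncertain. A smaller step is expected: a 2.0-fold higher number from compound 2 to compound 4 (0.30 log units; within the scatter). Compound 4 is estimated at 4000 nM, between 1000 nM and 20000 nM.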

Compound 4, concentration for 50% growth inhibition: 48000 nM
Compound 4: the middle estimate sits 12-fold (1.08 log units) below what was measured, and the stated range ends below it.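

In this assay, chloro in place of hydrogen on an aromatic carbon again weakens growth inhibition, with a 24-fold higher number from compound 2 to compound 4 (1.38 log units; beyond the scatter). The size of the step carries over from one core to the other: the same change on two cores in this assay, a 22-fold higher number (1.34 log units; beyond the scatter) from compound 1 to compound 3 and a 24-fold higher number (1.38 log units; beyond the scatter) from compound 2 to compound 4, 1.1-fold (0.04 log units) apart, within the scatter of two such steps. Among the compounds shown here, this agreement rests on only two pairs, and the chloro stands on different rings, in compound 4 on a ring that is part of a fused or bridged system of two rings, so it shows a matching size but neither a general rule for chloro on any ring of this series nor a reason for the loss.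

On these data alone, it remains open whether chloro at the place it holds in compound 4 gives a similar step on the core of compound 1, which would test the same place on a second core. As far as these compounds go, it also remains open whether a methoxy group or an amine at that place would weaken growth inhibition as chloro does.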